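Bromo in place of nitro at the assay limit

A few compounds are considered here, and "the series" means these few. Any claim that something is new, unique, unknown or untested is made for them only; others in the source may bear on it.

In a functional assay on 4T1 cells (Homo sapiens) for cytotoxicity, read by MTT assay, with a stated time of 48 h (on this read-out higher numbers stand for weaker inhibition and lower numbers for stronger inhibition), compound 1 `CCn1c(/C=C2/C(=O)Nc3ccccc32)nc2ccccc21` gives > 50000 nM as a limit, not a number. Compound 2 `Cn1c(/C=C2/C(=O)Nc3ccc([N+](=O)[O-])cc32)nc2ccccc21` gives > 50000 nM as a limit too. Compound 3 `Cn1c(/C=C2/C(=O)Nc3ccc(Br)cc32)nc2ccccc21` is not yet measured, and it differs from compound 2 by bromo in place of nitro on an aromatic carbon with bromo in place of nitro on an aromatic carbon. The data so far show the limit of > 50000 nM in this assay, at which 2 of the 2 values shown sit, and offer no direction for a change. The expected step of a number no higher from compound 2 to compound 3 (the limit leaves the size open) is small, with no shift beyond the scatter. In this assay compound 3 is estimated at 50000 nM with 20000 nM to 100000 nM as the expected span.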

Compound 3, half-maximal inhibitory concentration: > 50000 nM
Compound 3: no number, only a limit (the forecaster's own chance of this, stated with the estimate: 65%); the middle value lies on the limit itself.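

Among these compounds, no step from compound 2 to compound 3 can be read in this assay, as both give only a limit: the limit of > 50000 nM in this assay, at which 3 of the 3 values shown sit. Whether bromo or nitro makes any difference to cytotoxicity remains open with the compounds shown.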